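This account rests on a few compounds, and the source may have more. Where it says the series, first, only, none or still open, it means among the compounds named here.

Within the data shown here, in a functional assay on HCT-116 cells (Homo sapiens) for antiproliferative activity, read by MTT assay, with a stated time of 48 h (on this read-out higher numbers stand for weaker inhibition and lower numbers for stronger inhibition), compound 2 `CCCCCCCCC(CCO)n1cnc2c(NC)ncnc21` gives 3730 nM, the only actual number so far. Compound 1 `CCCCCCC(CCO)n1cnc2c(N)ncnc21`, with a shorter chain and amino instead of methylamino, is recorded only as a limit, > 50000 nM. Compound 3 `CCCCCCCCC(CCO)n1cnc2c(N)ncnc21` keeps the chain of compound 2 and turns methylamino to amino: hydrogen in place of methyl on a nitrogen on an aromatic ring. Among the measured compounds shown here, compound 1 is the only measured amino compound and its limit is > 50000 nM, so a moderate weakening beyond the scatter is expected in this assay. The expected change is a 2.4-fold higher number from compound 2 to compound 3 (0.38 log units; beyond the scatter). For compound 3 the estimated value is 9000 nM, within an expected range of 2500 nM to 35000 nM.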

Compound 3, half-maximal inhibitory concentration: 11600 nM
For compound 3 the middle estimate is 1.3-fold (0.11 log units) below the measured one, within the range that was stated.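

In this assay the methyl on the nitrogen on an aromatic ring now has a measured size with the chain held fixed: hydrogen in its place gives a 3.1-fold higher number from compound 2 to compound 3 (0.49 log units; beyond the scatter) in this comparison. With amino held fixed, ethyl in place of hydrogen on the saturated chain carbon gives an at least 4.3-fold lower number from compound 1 to compound 3 (0.63 log units; beyond the scatter) as a second, separate step. That second step is only a bound, as compound 1 is recorded solely as a limit: the limit of > 50000 nM in this assay, at which 1 of the 3 values shown sits. The compounds shown leave open how an ethyl or a cyclopropyl on that nitrogen would read, and whether a still longer chain would move the number further.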